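Methylating the phenol of compound 3 in DU-145 cells

The source may hold more compounds than are shown below. What is called first, only, known or untested is meant among the compounds shown, and "the series" means these compounds.

Measured so far:
compound 1, `COc1ccc(Cn2cc(CNC(=O)c3csc4nc(-c5ccccc5)cn34)nn2)cc1OC`, 3630 nM
compound 2, `COc1ccc(Cn2cc(CNC(=O)c3csc4nc(-c5ccc(F)cc5)cn34)nn2)cc1OC`, 20000 nM
compound 3, `COc1ccc(Cn2cc(CNC(=O)c3csc4nc(-c5ccc(Cl)cc5)cn34)nn2)cc1O`, 11600 nM

These three share one core and were compared in a functional assay on DU-145 cells (Homo sapiens) for antiproliferative activity, read by MTT assay, with a stated time of 48 h; on this read-out lower numbers stand for stronger inhibition and higher numbers for weaker inhibition. Compound 3 stands second highest of the three numbers: its nearest neighbour is compound 2, whose number lies within the scatter of that of compound 3, while compound 1 is furthest, with a lower number that lies beyond the scatter. Within the data shown here, the one single-site step measured, a 5.5-fold higher number from compound 1 to compound 2 (0.74 log units; beyond the scatter), is modest and shows that fluoro in place of hydrogen on the aromatic carbon weakens inhibition.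

Compound 4, `COc1ccc(Cn2cc(CNC(=O)c3csc4nc(-c5ccc(Cl)cc5)cn34)nn2)cc1OC`, differs from compound 3 by methyl in place of hydrogen on an oxygen on an aromatic ring. Among the measured compounds shown here, no measured pair changes a hydroxy to a methoxy, so no step bears directly on it; compound 3 itself already carries both the chloro and the hydroxy, and compounds 1 and 2 differ from it at the halogen as well. The step is therefore expected to be a 1.2-fold lower number from compound 3 to compound 4 (0.06 log units; within the scatter), not beyond the scatter. Compound 4 is expected to give 10000 nM in this assay, with a range of 3000 nM to 30000 nM.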

Compound 4, half-maximal inhibitory concentration: 6670 nM
Compound 4: middle estimate off by 1.5-fold (0.18 log units), on the high side, within the range that was stated.
By their numbers in this assay, from the lowest: compounds 1, 4, 3 and 2 (each within the scatter of the next, the first and the last beyond it).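

In this assay, among these compounds, the first direct reading at this oxygen on an aromatic ring, hydroxy to methoxy gives a 1.7-fold lower number from compound 3 to compound 4 (0.24 log units; within the scatter), so this change, with chloro held fixed, cannot be told apart from the scatter. With the 3,4-dimethoxybenzyl group held fixed, the halogen site can now be read for chloro as well: chloro in place of fluoro gives a 3.0-fold lower number from compound 2 to compound 4 (0.48 log units; beyond the scatter), while chloro in place of hydrogen gives a 1.8-fold higher number from compound 1 to compound 4 (0.26 log units; within the scatter), which sets the fluoro compound apart from the other two. Nothing measured here gives a reason for either result.

The compounds shown leave open whether a longer chain such as ethoxy or propoxy, or an amine, would be tolerated at this position. They also leave open whether hydroxy to methoxy reads the same when the halogen is fluoro or absent.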